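Anilino linker replaces aryl ether in thromboxane antagonist series

A few compounds are considered here, and "the series" means these few. Any claim that something is new, unique, unknown or untested is made for them only; others in the source may bear on it.

Three sulfonylurea compounds sharing one core have been measured in a functional assay on HEK293 cells for antagonist activity at thromboxane A2 receptor (Homo sapiens), read by fluorescence and calcium flux; a lower number here means a stronger inhibitor, a higher number a weaker inhibitor. Compound 1 `Cc1ccccc1Oc1ccc(C#N)cc1S(=O)(=O)NC(=O)NC(C)(C)C` gives 3690 nM, compound 2 `CC(C)(C)NC(=O)NS(=O)(=O)c1cc(C#N)ccc1Oc1ccc(Cl)cc1` gives 5640 nM, and compound 3 `CC(C)(C)NC(=O)NS(=O)(=O)c1cc(C#N)ccc1Oc1ccc(Br)cc1` gives 5880 nM. Compound 3 carries the highest number of the three, yet the steps that lead to it are a 1.0-fold higher number from compound 2 to compound 3 (0.02 log units; within the scatter) and a 1.6-fold higher number from compound 1 to compound 3 (0.20 log units; within the scatter), so all three sit within the usual scatter of one another.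

Compound 4 `Cc1ccccc1Nc1ccc(C#N)cc1S(=O)(=O)NC(=O)NC(C)(C)C` has not yet been measured in this assay. It differs from compound 3 by (2-methylphenyl)amino in place of 4-bromophenoxy on an aromatic carbon.

Part of this change is already covered: the swap of the aryl group on the oxygen gave a 1.6-fold higher number from compound 1 to compound 3 (0.20 log units; within the scatter), and the halogen exchange gave a 1.0-fold higher number from compound 2 to compound 3 (0.02 log units; within the scatter), neither beyond the scatter. Among the measured compounds shown here, the replacement of the oxygen link by the amino link has no counterpart among the measured compounds, so it adds uncertainty but no known direction. Compound 4 is therefore expected to land near compound 1, with a step of a 1.7-fold lower number from compound 3 to compound 4 (0.23 log units; within the scatter) that is not expected to exceed the scatter. Compound 4 is estimated at 3500 nM, ranging from 1200 nM to 10000 nM.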

Compound 4, half-maximal inhibitory concentration: 2750 nM
Beside the measured number, compound 4's estimate is 1.3-fold (0.10 log units) above it, and the stated range covers the measured number.
By their numbers in this assay, from the lowest: compounds 4, 1, 2 and 3 (each within the scatter of the next, the first and the last beyond it).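

With compound 4, the amino link can be read directly against the oxygen link, with the 2-methylphenyl group kept: a 1.3-fold lower number from compound 1 to compound 4 (0.13 log units; within the scatter), so in this assay this exchange alone stays within the scatter. Among the compounds shown here, the steps from the halogenated aryl ethers are the first in the set to pass beyond the scatter, at a 2.1-fold lower number from compound 3 to compound 4 (0.33 log units; beyond the scatter) and a 2.1-fold lower number from compound 2 to compound 4 (0.31 log units; beyond the scatter), but each changes both the link and the aryl group, and the two parts taken singly, as in a 1.6-fold higher number from compound 1 to compound 3 (0.20 log units; within the scatter) and a 1.3-fold lower number from compound 1 to compound 4 (0.13 log units; within the scatter), do not pass it. The separation across the series is therefore modest and appears only between the two ends of the order, while no measurement shown here accounts for it.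

On these data alone, what a 4-bromophenyl or 4-chlorophenyl group would give on the amino link remains open, as does whether a methylene link or a methylated amino link would read like the amino link in compound 4. Also open, as far as these compounds go, is what would follow from replacing the nitrile with a carboxylic acid, or the tert-butyl group on the urea with a cyclohexyl group, since both stay fixed in all four compounds.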